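A few compounds are considered here, and "the series" means these few. Any claim that something is new, unique, unknown or untested is made for them only; others in the source may bear on it.

Compound 3 `COC(=O)c1ccc(NCc2cncn2Cc2ccc(OC)cc2)cc1-c1ccccc1` is the starting point of this step. In a toxicity assay on NIH3T3 cells (Mus musculus) for cytotoxicity, read by resazurin assay (on this read-out lower numbers stand for an effect already at smaller amounts and higher numbers for an effect only at larger amounts of compound), compound 3 gives "not determined" (no result reported), so no number places it among the other compounds. The nearest comparisons are compound 1 `COC(=O)c1ccc(NCc2cncn2Cc2ccccc2Cl)cc1-c1ccccc1`, which in this assay gives 10000 nM, and compound 2 `COC(=O)c1ccc(NCc2cncn2Cc2ccc(N)cc2)cc1-c1ccccc1`. For compound 2 the result in this assay is a limit of the assay, > 10000 nM. The step of a number no lower from compound 1 to compound 2 (the limit leaves the size open) therefore has a size that cannot be read, as the limit of > 10000 nM in this assay, at which 1 of the 3 values shown sits, leaves it open. Compound 4 `COC(=O)c1ccc(NCc2cncn2Cc2ccc(Br)cc2)cc1-c1ccccc1` differs from compound 3 in one place: bromo in place of methoxy on an aromatic carbon. Among the measured compounds shown here, no measured step concerns this exchange, and the only step on record, a number no lower from compound 1 to compound 2 (the limit leaves the size open), involves a different part of the molecule, so it gives no direction for the bromo in place of methoxy change. The results that exist cluster at the weak end of the assay. Compound 4 is therefore expected to land in the same region, with a number estimated at 10000 nM, ranging from 4000 nM to 25000 nM, and a fair chance that only a limit is reported.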

Compound 4, half-maximal effective concentration: > 10000 nM
Compound 4 ended at the assay's limit; the forecaster's own chance of this, stated with the estimate: 50%; the middle value sits exactly at the limit.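

Compound 4 is a second compound whose result in this assay is a limit rather than a number: the limit of > 10000 nM in this assay, at which 2 of the 4 values shown sit. Bromo on this aromatic carbon, para to a large group, therefore gives the same kind of result as amino in compound 2, whereas the 2-chlorophenyl compound 1 has a number, 10000 nM. Among the new steps stands a number no lower from compound 1 to compound 4 (the limit leaves the size open) and, like all the new steps to compound 4, its size cannot be read, so no order among these three compounds can be stated.

As far as these compounds go, it remains open whether the results for compound 2 and compound 4 truly differ from each other or from that of compound 1, and where compound 3 with its methoxy stands. Also open, from the compounds shown here alone, is whether a carboxylic acid or a fluoro on this same carbon would give a number in this assay.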